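Series notes: from compound 2 to compound 3

This account rests on a few compounds, and the source may have more. Where it says the series, first, only, none or still open, it means among the compounds named here.

In a functional assay on MCF7 cells (Homo sapiens) for inhibition, read by MTT assay (on this read-out higher numbers stand for weaker inhibition and lower numbers for stronger inhibition), compound 1 (`COc1cc2ncnc(Nc3ccc(NC(=O)c4ccccc4C)cc3)c2cc1OC`) gives 21000 nM. Compound 2 (`COc1cc2ncnc(Nc3ccc(NC(=O)c4ccccc4OC)cc3)c2cc1OC`) reads > 100000 nM, which is a limit of the assay and not a number. It therefore has no measured value to anchor a step, as the limit of > 100000 nM in this assay, at which 1 of the 2 values shown sits, records.

Compound 3 (`COc1cc2ncnc(Nc3ccc(NC(=O)c4ccc(C(C)(C)C)cc4)cc3)c2cc1OC`) carries 4-(tert-butyl)phenyl in place of 2-methoxyphenyl on a carbonyl carbon.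

For the measured compounds named here, only one measured step bears on this, and only loosely: an at least 4.7-fold higher number from compound 1 to compound 2 (0.67 log units; beyond the scatter), with methoxy in place of methyl on an aromatic carbon, lies beyond the scatter. Compound 3 loses that methoxy, and compound 1, also without it, gives 21000 nM, so a lower number is expected in this assay. The expected change is an at least 3.3-fold lower number from compound 2 to compound 3 (0.52 log units; beyond the scatter). For compound 3 the estimate is 30000 nM, with an expected range of 9000 nM to 100000 nM.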

Compound 3, half-maximal inhibitory concentration: > 100000 nM
Compound 3: no number, only a limit; the forecaster's own chance of this, stated with the estimate: 30%; at least 3.3-fold (0.52 log units) between middle value and limit.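

In this assay, for the compounds shown here, exchanging the aromatic group on the carbonyl carbon for 4-(tert-butyl)phenyl gives an at least 4.7-fold higher number from compound 1 to compound 3 (0.67 log units; beyond the scatter), so the methoxy of compound 2 is not the only change at this place that loses the measurable activity of compound 1. Compound 3 reads > 100000 nM, which is a limit of the assay and not a number, so the absence of methoxy alone does not bring a measurable value back. The step from compound 2 to compound 3 cannot be read, and only compound 1 keeps a number in the series: the limit of > 100000 nM in this assay, at which 2 of the 3 values shown sit.

Going by these compounds, how far compound 2 and compound 3 lie past that limit remains open, so the two cannot be ordered. On these data alone, it is also open whether an unsubstituted phenyl, or a phenyl carrying an amine or a carboxylic acid, would give a number in this assay.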